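Shortening the amide chain in a cyclopentyl-bearing series

The source may hold more compounds than are shown below. What is called first, only, known or untested is meant among the compounds shown, and "the series" means these compounds.

Measured so far in a functional assay on MCF7 cells (Homo sapiens) for antiproliferative activity, read by CCK-8 assay, with a stated time of 72 h; on this read-out higher numbers stand for weaker inhibition of growth and lower numbers for stronger inhibition of growth:
compound 1, `CC[C@@H]1C(=O)N(C)c2cnc(-n3ccc4cc(C(=O)NCC(C)C)ccc43)nc2N1C1CCCC1`, gives 953 nM;
compound 2, `CC[C@@H]1C(=O)N(C)c2cnc(-n3ccc4cc(C(=O)NC5CCCC5)ccc43)nc2N1C1CCCC1`, gives 795 nM;
compound 3, `CCCCNC(=O)c1ccc2c(ccn2-c2ncc3c(n2)N(C2CCCC2)[C@H](CC)C(=O)N3C)c1`, gives 634 nM.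

Compound 3 stands within the scatter of both of its neighbours: a 1.5-fold lower number from compound 1 to compound 3 (0.18 log units; within the scatter) and a 1.3-fold lower number from compound 2 to compound 3 (0.10 log units; within the scatter). Compound 4, `CCCNC(=O)c1ccc2c(ccn2-c2ncc3c(n2)N(C2CCCC2)[C@H](CC)C(=O)N3C)c1`, differs from compound 3 in one place: hydrogen in place of methyl on a saturated chain carbon, three bonds along the chain from an amide-type nitrogen. The measured steps that bear on this all alter the group on the amide-type nitrogen: a 1.2-fold lower number from compound 1 to compound 2 (0.08 log units; within the scatter), a 1.3-fold lower number from compound 2 to compound 3 (0.10 log units; within the scatter) and a 1.5-fold lower number from compound 1 to compound 3 (0.18 log units; within the scatter). None of them went beyond the scatter, so on these three compounds this part of the molecule has hardly moved the number. Compound 4 is therefore expected to stay close, with a 1.1-fold higher number from compound 3 to compound 4 (0.04 log units; within the scatter) and nothing beyond the scatter. The estimate for compound 4 in this assay is 700 nM, within the range 350 nM to 1400 nM.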

Compound 4, concentration for 50% growth inhibition: 592 nM
Estimate against measurement, compound 4: 1.2-fold (0.07 log units) above; the measured number falls inside the stated range.
By their numbers in this assay, from the lowest: compounds 4, 3, 2 and 1 (each within the scatter of the next).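

Shortening butyl to propyl on the amide-type nitrogen in this assay gives a 1.1-fold lower number from compound 3 to compound 4 (0.03 log units; within the scatter) and so shows that this position accepts the loss of a methyl without leaving the scatter. The propyl group also stays within the scatter of the cyclopentyl and isobutyl groups, with a 1.3-fold lower number from compound 2 to compound 4 (0.13 log units; within the scatter) and a 1.6-fold lower number from compound 1 to compound 4 (0.21 log units; within the scatter) as the two steps. No available evidence explains this flat response.

The compounds shown leave open whether an ethyl, a methyl or a much longer chain on this nitrogen would move the number beyond the scatter. The same question stands for an amine or a carboxylic acid carried on the propyl chain.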